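The source may hold more compounds than are shown below. What is called first, only, known or untested is meant among the compounds shown, and "the series" means these compounds.

Measured so far:
Compound 1, `COc1cc(O)c2c(=O)cc(-c3ccccc3Cl)oc2c1CN1CCCCC1`, gives 21500 nM.
Compound 2, `COc1cc(OC)c(C(=O)/C=C/c2ccccc2Cl)c(O)c1CN(C)CCCN(C)C`, gives 3800 nM.

Both numbers come from a functional assay on ECa-109 cells (Homo sapiens) for antiproliferative activity, with a stated time of 72 h; a lower number here means a stronger inhibitor, a higher number a weaker inhibitor. Of the two, compound 2 stands at the lower number, and since the gap to compound 1 lies beyond the usual scatter of repeated measurements, compound 2 is the stronger inhibitor of the pair. The two compounds share no single-point change, so nothing more can be read from their comparison than what the two values show.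

Compound 3, `COc1cc(OC)c(C(=O)/C=C/c2ccccc2Cl)c(O)c1CN(C)C`, has not yet been measured. It differs from compound 2 in one place: hydrogen in place of 2-(dimethylamino)ethyl on a saturated chain carbon bound to an amine nitrogen. The longer amine-bearing chain of compound 2 is thus cut back to a dimethylamino group on the shared core.

Among the compounds with values here, no measured pair tells how much this kind of change matters, so the expectation must rest on compound 2 alone, whose value in this assay is 3800 nM. The step from compound 2 to compound 3 is expected to be modest and to go toward a weaker inhibitor, about a 1.8-fold higher number from compound 2 to compound 3 (0.27 log units; within the scatter). Compound 3 is therefore estimated at 7000 nM, with a range from 2500 nM to 20000 nM.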

Compound 3, half-maximal inhibitory concentration: 2600 nM
The estimate for compound 3 lay 2.7-fold (0.43 log units) above the measured number; measured number inside the range.
By their numbers in this assay, from the lowest: compounds 3 and 2 (each within the scatter of the next); then compound 1.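

In this assay, the step that replaces 2-(dimethylamino)ethyl with hydrogen on a saturated chain carbon bound to an amine nitrogen is a 1.5-fold lower number from compound 2 to compound 3 (0.16 log units; within the scatter), so the two compounds cannot be told apart in this test. Within the data shown here, this is the first direct look at this position, and it shows that the whole 2-(dimethylamino)ethyl group, including its amine nitrogen, can be removed from the side chain without a difference beyond the scatter, leaving the shorter (dimethylamino)methyl group on the shared core. No measurement shown here offers an explanation for this result.

Still open, as far as these compounds go, is whether a different group at this place, such as a carboxylic acid, a morpholine ring or a much longer carbon chain, would shift the number beyond the scatter, or whether this position accepts such groups as readily as it accepts the two seen here. Also open, from the compounds shown here alone, is whether the (dimethylamino)methyl group itself matters, since compound 1 differs from compound 2 and compound 3 in more than one place and cannot answer that question.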